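The source may report more compounds than this note shows. Statements on the series, on what has been measured and on what is new or still open speak of the compounds shown alone.

Measured so far:
compound 1 `CC1=C(CC/C(C)=C/CC/C(C)=C/C[C@@H](O)C2=CC(=O)OC2)C(C)(C)CCC1`: > 10000 nM
compound 2 `CC1=C(CC/C(C)=C/CC/C(C)=C/CCC2=CC(=O)OC2O)C(C)(C)CCC1O`: > 10000 nM

In a functional assay on T47D cells (Homo sapiens) for antiproliferative activity, read by sulforhodamine B assay, with a stated time of 48 h (on this read-out higher numbers stand for weaker inhibition and lower numbers for stronger inhibition), compound 1 gives only a limit, > 10000 nM. In this assay compound 2 likewise gives only a limit, > 10000 nM. For the measured compounds named here, compound 2 therefore stands at the limit, and the one further value shown is also a limit, so neither compound can be placed above or below the other. The whole picture so far is summed up by the limit of > 10000 nM in this assay, at which 2 of the 2 values shown sit.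

Compound 3 `CC1=C(CC/C(C)=C/CC/C(C)=C/CCC2=CC(=O)OC2O)C(C)(C)CCC1` has not yet been measured in this assay. It differs from compound 2 as follows: hydrogen in place of hydroxy on a saturated ring carbon. Going by the values given here, no step between measured compounds exists to calibrate this change. With both measured values at the limit, the step that the limit leaves unreadable from compound 2 to compound 3 is expected to be none beyond the scatter. Compound 3 is estimated at 15000 nM, with a range of 5000 nM to 50000 nM, most likely reported again only as a limit.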

Compound 3, half-maximal inhibitory concentration: 5100 nM
The estimate for compound 3 lay 2.9-fold (0.47 log units) above the measured number; measured number inside the range.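

In this assay, for the compounds shown here, compound 3 gives 5100 nM, the first value that is a number and not a limit. Hydrogen in place of hydroxy on the saturated ring carbon gives an at least 1.9-fold lower number from compound 2 to compound 3 (0.29 log units; that floor lies within the scatter), so the hydroxy at this position is not required for a value inside the measured range, although the true size of the step stays unread. The exchange of the oxygen-bearing five-membered ring group on the saturated chain carbon bound to a double-bonded chain carbon gives an at least 1.9-fold lower number from compound 1 to compound 3 (0.29 log units; that floor lies within the scatter), and that step too is only a floor.

From the compounds shown here alone, whether either change moves the number beyond the scatter stays open, with most of the series resting on one limit: the limit of > 10000 nM in this assay, at which 2 of the 3 values shown sit. Also open is how an amine or a carboxylic acid would read in place of the hydroxy on the saturated ring carbon.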